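From Fluoro to Trifluoromethyl on the Aromatic Ring

The source may report more compounds than this note shows. Statements on the series, on what has been measured and on what is new or still open speak of the compounds shown alone.

Of the compounds shown here, three on a shared core have been measured in a functional assay on CHO cells for agonist activity at Free fatty acid receptor 1 (Homo sapiens), read by FLIPR and calcium flux, tested at 100 nM; a lower number here means a weaker effect, a higher number a stronger effect of the compound at the concentration tested. Compound 1 `Cc1nc(-c2cccc(Cl)c2)sc1COc1ccc2c(c1)OCC2CC(=O)O` gives 43%, compound 2 `Cc1nc(-c2ccc(Cl)cc2)sc1COc1ccc2c(c1)OCC2CC(=O)O` gives 53.4%, and compound 3 `Cc1nc(-c2ccc(F)cc2)sc1COc1ccc2c(c1)OCC2CC(=O)O` gives 61.6%, the highest of the three numbers; the nearest is compound 2, with a number 8.2 percentage points higher from compound 2 to compound 3 (within the scatter), while compound 1 lies further away, with a number 18.6 percentage points higher from compound 1 to compound 3 (beyond the scatter). Compound 4 `Cc1nc(-c2ccc(C(F)(F)F)cc2)sc1COc1ccc2c(c1)OCC2CC(=O)O` differs from compound 3 by trifluoromethyl in place of fluoro on an aromatic carbon. The step that bears most closely on this change is a number 8.2 percentage points higher from compound 2 to compound 3 (within the scatter), which exchanged one halogen for another on an aromatic carbon; the moves a number 10.4 percentage points higher from compound 1 to compound 2 (beyond the scatter) and a number 18.6 percentage points higher from compound 1 to compound 3 (beyond the scatter) concern a change of position and speak less directly. A step of a number 9.6 percentage points lower from compound 3 to compound 4 (within the scatter) is therefore expected, within the scatter. For compound 4 the estimate in this assay is 52%, with a range from 30% to 72%.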

Compound 4, a percentage reported as activity, at one concentration (the size of the read-out at that concentration, not a potency): 50.4%
Estimate against measurement, compound 4: 1.6 percentage points above, within the range that was stated.
By their numbers in this assay, from the lowest: compounds 1, 4, 2 and 3 (each within the scatter of the next, the first and the last beyond it).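

Replacing fluoro with trifluoromethyl on this aromatic carbon, para to a large group, gives a change beyond the scatter in this assay (a number 11.2 percentage points lower from compound 3 to compound 4 (beyond the scatter)), whereas replacing chloro with trifluoromethyl at the same place stays within it (a number 3 percentage points lower from compound 2 to compound 4 (within the scatter)). Chloro thus lies within the scatter of both fluoro and trifluoromethyl, so only those two groups are separated here, and the 3-chlorophenyl compound also stays within the scatter of compound 4 (a number 7.4 percentage points higher from compound 1 to compound 4 (within the scatter)). As far as these compounds go, whether an amine or a nitrile on this carbon would stand apart from fluoro remains open. Nothing available here explains the fall from fluoro to trifluoromethyl.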